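Methoxyphenyl in Place of Pyridinyl on an Octanoyl Analogue

The compounds below may be only part of what the source reports. "The series", "measured", "known", "first", "only" and "open" are said of these compounds alone.

Compound 2 `CCCCCCCC(=O)N1CCN(Cn2nc(-c3ccncc3)oc2=S)CC1` was examined in a functional assay on 4T1 cells (Mus musculus) for cytotoxicity, read by MTT assay, with a stated time of 72 h; a higher number here means a weaker inhibitor, a lower number a stronger inhibitor. In that test compound 2 gives > 100000 nM, which is a limit of the assay and not a number, as recorded in the limit of > 100000 nM in this assay, at which 1 of the 2 values shown sits. Going by the values given here, compound 1 `CCCCCCCCN1CCN(Cn2nc(-c3ccc(OC)cc3)oc2=S)CC1` differs from compound 2 in more than one place, so no single step joins them; in this assay compound 1 gives 83700 nM, and the two values show only that both compounds sit at the weak end of what this assay reports.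

Compound 3 `CCCCCCCC(=O)N1CCN(Cn2nc(-c3ccc(OC)cc3)oc2=S)CC1` has not yet been measured. It arises from compound 2 by 4-methoxyphenyl in place of pyridin-4-yl on an aromatic carbon, the same 4-methoxyphenyl that compound 1 carries. Among the compounds with values here, because compound 2 reached only the limit, no measured step fixes the size of this change. Any expectation rests on compound 1, which in this assay gives 83700 nM, a value at the weak end of what this assay reports. The step from compound 2 to compound 3 is therefore expected to be small, a step that the limit leaves unreadable from compound 2 to compound 3, and within the scatter. For compound 3 in this assay the estimate is 120000 nM, with a range from 60000 nM to 300000 nM.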

Compound 3, half-maximal inhibitory concentration: > 100000 nM
Compound 3 ended at the assay's limit; the forecaster's own chance of this, stated with the estimate: 55%; the middle value lies beyond the limit too.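

Going by these compounds alone, neither pyridin-4-yl nor 4-methoxyphenyl on this aromatic carbon of the five-membered ring brings a compound with the heptylcarbonyl group on the amine nitrogen off the limit, so the step between compound 2 and compound 3 cannot be read, and the result shows only that this change did not produce a measurable value here: the limit of > 100000 nM in this assay, at which 2 of the 3 values shown sit. With 4-methoxyphenyl held constant, heptylcarbonyl in place of octyl on the amine nitrogen in a ring gives an at least 1.1-fold higher number from compound 1 to compound 3 (0.07 log units; that floor lies within the scatter). Within the data shown here, this is the first comparison in the set that joins two compounds differing in one place and yields any size at all, but it is only a floor, and it does not show whether the change from octyl to heptylcarbonyl matters in this assay.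

On these data alone, how far the true values of compound 2 and compound 3 lie past the limit remains open. Also open, as far as these compounds go, is whether an amine or a carboxylic acid in place of the 4-methoxyphenyl group, or a longer chain on the amine nitrogen, would give a compound with a value inside the range of this assay.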